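The source may hold more compounds than are shown below. What is called first, only, known or untested is meant among the compounds shown, and "the series" means these compounds.

Measured compounds in a functional assay (muscle tissue) with Cavia porcellus as the target; a lower number here means that less compound is needed, a higher number that more compound is needed for the effect:
- compound 1 `COC(=O)C1=C(C)N=C(C)/C(=C(\O)OC)C1c1ccc(I)cc1` gives 22900 nM
- compound 2 `COC(=O)C1=C(C)N=C(C)/C(=C(\O)OC)C1c1ccccc1N` gives 39800 nM
- compound 3 `COC(=O)C1=C(C)N=C(C)/C(=C(\O)OC)C1c1ccc(Cl)cc1Cl` gives 640 nM

Compound 2 stands highest of the three numbers. Its nearest neighbour is compound 1, and the step of a 1.7-fold higher number from compound 1 to compound 2 (0.24 log units; within the scatter) lies within the scatter, so the two cannot be ordered. Compound 3 lies furthest away, with a 62-fold lower number from compound 2 to compound 3 (1.79 log units; beyond the scatter) well beyond the scatter. Compound 4 `COC(=O)C1=C(C)N=C(C)/C(=C(\O)OC)C1c1ccccc1C(F)(F)F` differs from compound 2 in one place: trifluoromethyl in place of amino on an aromatic carbon.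

For the measured compounds named here, two measured steps bear on this change. The step of a 62-fold lower number from compound 2 to compound 3 (1.79 log units; beyond the scatter) shows that exchanging the amino-bearing aryl group for a dichlorinated one gives a large lower number, and a 36-fold lower number from compound 1 to compound 3 (1.55 log units; beyond the scatter) shows a similarly large lowering from a different starting aryl group. Compound 4 carries a single trifluoromethyl rather than two chlorines, so the resemblance to compound 3 is only partial, and a smaller step is expected. Compound 4 is therefore expected to give a lower number than compound 2, with an estimated step of a 10-fold lower number from compound 2 to compound 4 (1.00 log units; beyond the scatter). The estimate for compound 4 in this assay is 4000 nM, with a range from 800 nM to 20000 nM.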

Compound 4, half-maximal effective concentration: 1.51 nM
Estimate against measurement, compound 4: 2600-fold (3.42 log units) above; measured number outside the range, below it.
By their numbers in this assay, from the lowest: compound 4; then compound 3; then compounds 1 and 2 (each within the scatter of the next).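

Replacing amino with trifluoromethyl on this aromatic carbon, ortho to a large group, gives a 26000-fold lower number from compound 2 to compound 4 (4.42 log units; beyond the scatter) in this assay. The earlier compounds shown here showed large steps only on exchange of the whole aryl group, such as a 62-fold lower number from compound 2 to compound 3 (1.79 log units; beyond the scatter), whereas this result shows that one group at this single place can move the number much further. Nothing available here accounts for the size of this step.

As far as these compounds go, it remains open whether a methyl, a chlorine or a nitrile on this aromatic carbon would give a number close to that of compound 4, or whether the low number belongs to trifluoromethyl alone. Also open, from the compounds shown here alone, is whether trifluoromethyl would give a similar step on another carbon of the aromatic ring.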